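Methoxyphenyl relocation on the shared core: working notes

The compounds below may be only part of what the source reports. "The series", "measured", "known", "first", "only" and "open" are said of these compounds alone.

Values in a functional assay on U-87MG ATCC cells for antiproliferative activity against U-87 MG (Homo sapiens), read by MTT assay, with a stated time of 48 h; a higher number here means a weaker inhibitor, a lower number a stronger inhibitor:
Compound 1 `Cc1nc(-c2ccc(Cl)cc2)sc1C(=O)CSc1nc(-c2ccccc2)c(C#N)c(=O)[nH]1`: 27600 nM
Compound 2 `COc1ccc(-c2nc(SCC(=O)c3sc(-c4ccccc4)nc3C)[nH]c(=O)c2C#N)cc1`: 48400 nM

In this assay compound 2 gives 48400 nM, which lies within the scatter of the number for compound 1, so the two cannot be ranked. Going by the values given here, they differ in more than one place, and no measured pair isolates a single change.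

Compound 3 `COc1cccc(-c2nc(SCC(=O)c3sc(-c4ccccc4)nc3C)[nH]c(=O)c2C#N)c1` has the same atoms as compound 2, joined differently: 3-methoxyphenyl in place of 4-methoxyphenyl on an aromatic carbon. That carbon sits on a six-membered aromatic ring with 2 nitrogen, next to the ring nitrogen and ortho to a cyano group.

Among the compounds with values here, the data hold no measured step for this kind of change, in either direction. The expectation therefore rests on compound 2 at 48400 nM, and no change beyond the scatter is expected in this assay. The expected size is a 1.2-fold lower number from compound 2 to compound 3 (0.08 log units; within the scatter), which would stay within the scatter. Compound 3 is estimated at 40000 nM, with an expected range of 18000 nM to 90000 nM.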

Compound 3, half-maximal inhibitory concentration: 59700 nM
Beside the measured number, compound 3's estimate is 1.5-fold (0.17 log units) below it, and the stated range covers the measured number.
By their numbers in this assay, from the lowest: compounds 1, 2 and 3 (each within the scatter of the next, the first and the last beyond it).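

Going by these compounds alone, compound 2 and compound 3 form the first pair that differs in one place, so this position can now be read directly. On the aromatic carbon next to the ring nitrogen and ortho to a cyano group, 3-methoxyphenyl in place of 4-methoxyphenyl gives in this assay a 1.2-fold higher number from compound 2 to compound 3 (0.09 log units; within the scatter) and so leaves the two isomers unranked; with the rest of the molecule held constant, the choice between these two methoxyphenyl groups has no readable effect on this number. Nothing available bears on the reason for this outcome, and the result alone supports no explanation.

Going by these compounds, the pair covers only two placements of one methoxy group on one core, so it remains open whether a different substituent on this phenyl ring, such as a dimethylamino group or a carboxylic acid, would shift the number beyond the scatter. Compound 1 carries a phenyl at this position but also differs elsewhere, so the contribution of the methoxy group itself, relative to the bare phenyl, remains unresolved.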